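Swapping the dichlorophenyl for a dimethylphenyl on the shared core

The compounds below may be only part of what the source reports. "The series", "measured", "known", "first", "only" and "open" are said of these compounds alone.

Of the compounds shown here, three with a shared core have been measured in an ADME assay on microsomes from liver (Rattus norvegicus) for metabolic stability, read by LC-MS, using NADPH, at 37 degrees C; on this read-out lower numbers stand for a shorter-lived compound and higher numbers for a longer-lived compound. Compound 1 `Cc1oc(-c2c(Cl)cccc2Cl)nc1CN1CCC(C(=O)NCCCN2C[C@H](C)C[C@H](C)C2)CC1` gives 0.0483 h, which places it second highest of the three numbers. Its nearest neighbour is compound 3 `Cc1cccc(Cl)c1-c1nc(CN2CCC(C(=O)NCCCN3CCC(C(C)C)CC3)CC2)c(C)o1`, which in this assay gives 0.0333 h, a number that sits within the scatter of compound 1. The furthest is compound 2 `Cc1ccccc1-c1nc(CN2CCC(C(=O)NCCCCN3C[C@H](C)C[C@H](C)C3)CC2)c(C)o1`, which in this assay gives 0.2 h, a number beyond the scatter above compound 1. For the measured compounds named here, no step between two measured compounds differing in one place is available, so no measured step can be read directly.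

Compound 4 `Cc1ccc(-c2nc(CN3CCC(C(=O)NCCCN4C[C@H](C)C[C@H](C)C4)CC3)c(C)o2)c(C)c1` arises from compound 1 by a single change: 2,4-dimethylphenyl in place of 2,6-dichlorophenyl on an aromatic carbon. Because compound 2, whose aromatic ring carries a methyl rather than chlorines but which differs elsewhere as well, gives 0.2 h, the account expects a step upward from compound 1 to compound 4 in this assay of modest size, a 1.7-fold higher number from compound 1 to compound 4 (0.22 log units; within the scatter), not clearly beyond the scatter. Compound 4 is therefore estimated in this assay at 0.08 h, within a range from 0.03 h to 0.22 h.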

Compound 4, half-life: > 0.5 h
Compound 4 gave a limit, no number (the forecaster's own chance of this, stated with the estimate: 5%); middle value at least 6.2-fold (0.79 log units) away from the limit.
By their numbers in this assay, from the lowest: compounds 3 and 1 (each within the scatter of the next); then compound 2. At a limit, above all of these: compound 4.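

In this assay, the change on this aromatic carbon, next to the ring nitrogen and next to the ring oxygen, gives an at least 10-fold higher number from compound 1 to compound 4 (1.01 log units; beyond the scatter). This is the only step shown in which the rest of the molecule stays fixed, so it ties a large change in half-life to this place alone, which compounds 1, 2 and 3 could not do. The size of the step is bounded on one side only, as the value for compound 4 is a limit and not a number: the limit of > 0.5 h in this assay, at which 1 of the 4 values shown sits.

Going by these compounds, whether the step follows from the loss of the two chlorines or from the gain of the two methyl groups stays open, as does the standing of an unsubstituted phenyl or a fluorophenyl at this place. Also open, on these data alone, is whether 2,4-dimethylphenyl acts alike with the side chain of compound 3.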